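The source may hold more compounds than are shown below. What is called first, only, known or untested is meant among the compounds shown, and "the series" means these compounds.

In a functional assay on the whole organism with Mus musculus as the target (on this read-out lower numbers stand for an effect already at smaller amounts and higher numbers for an effect only at larger amounts of compound), compound 1 `CCc1c(OC)nc2nc(-c3noc(C)n3)cn2c1C` gives 7.4 mg/kg and compound 2 `CCCc1c(OC)nc2nc(-c3noc(C)n3)cn2c1C` gives 13 mg/kg. Among the measured compounds shown here, compound 1 therefore stands within the scatter of its only measured neighbour: a 1.8-fold higher number from compound 1 to compound 2 (0.24 log units; within the scatter). Compound 3 `CCc1c(OC)nc2nc(-c3nnc(C)o3)cn2c1C` carries 5-methyl-1,3,4-oxadiazol-2-yl in place of 5-methyl-1,2,4-oxadiazol-3-yl on an aromatic carbon. For the measured compounds named here, the one measured step lies on the saturated chain, so no measured step tests this swap and none gives it a size or direction. In this assay no step beyond the scatter is expected, though with wide uncertainty. The expected step is a 1.5-fold higher number from compound 1 to compound 3 (0.17 log units; within the scatter). For compound 3 the estimated value is 11 mg/kg, with an expected range from 3.5 mg/kg to 35 mg/kg.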

Compound 3, dose for half-maximal effect: 20 mg/kg
Compound 3: middle estimate off by 1.8-fold (0.26 log units), on the low side; measured number inside the range.
By their numbers in this assay, from the lowest: compounds 1, 2 and 3 (each within the scatter of the next, the first and the last beyond it).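

On the aromatic carbon of the five-membered aromatic ring, the change to 5-methyl-1,3,4-oxadiazol-2-yl gives a 2.7-fold higher number from compound 1 to compound 3 (0.43 log units; beyond the scatter) in this assay, a modest step and the first beyond the scatter in this series. The entering and leaving groups count alike in atoms, donors and acceptors, so only the way the ring atoms are joined separates compound 1 from compound 3. Nothing available bears on the reason for this step.

As far as these compounds go, whether the same swap has a similar size on the longer chain of compound 2 remains open. From the compounds shown here alone, how a carboxylic acid or an amine at this aromatic carbon would compare also remains open.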